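Swapping methoxycarbonyl for cyano on the chain

The source may report more compounds than this note shows. Statements on the series, on what has been measured and on what is new or still open speak of the compounds shown alone.

Compound 1 `COc1ccc(-c2cc3c(OC)cc(OC)cc3n(CCCC#N)c2=O)cc1`: 10000 nM
Compound 2 `COC(=O)CCn1c(=O)c(-c2ccc(OC)cc2)cc2c(OC)cc(OC)cc21`: 10000 nM

In a functional assay on A-427 cells (Homo sapiens) for cytotoxicity, read by colorimetric assay and MTT assay (a higher number here means a weaker inhibitor, a lower number a stronger inhibitor), compound 2 gives 10000 nM, level with compound 1 at 10000 nM. Compound 3 `COc1ccc(-c2cc3c(OC)cc(OC)cc3n(CCC#N)c2=O)cc1` has not been measured yet. It differs from compound 2 by cyano in place of methoxycarbonyl on a saturated chain carbon, two bonds along the chain from an aromatic nitrogen. Going by the values given here, only one measured step bears on this change, no change at the digits printed from compound 1 to compound 2 (within the scatter), where methoxycarbonyl replaced cyanomethyl. With a single step as evidence, no shift beyond the scatter is expected, and the expected step is no change at the digits printed from compound 2 to compound 3 (within the scatter). In this assay the estimate for compound 3 is 10000 nM, within an expected range of 4000 nM to 20000 nM.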

Compound 3, half-maximal inhibitory concentration: 10000 nM
For compound 3 middle estimate and measured number coincide at the digits printed, within the range that was stated.
By their numbers in this assay, from the lowest: compounds 1, 2 and 3 (each within the scatter of the next).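

In this assay there is no change at the digits printed from compound 2 to compound 3 (within the scatter) when cyano replaces methoxycarbonyl, and no change at the digits printed from compound 1 to compound 3 (within the scatter) when cyano replaces cyanomethyl. At this saturated chain carbon, two bonds along the chain from an aromatic nitrogen, the 2-cyanoethyl group therefore reads the same as both the 2-(methoxycarbonyl)ethyl group and the chain of compound 1, so none of these three groups separates from the others. No measurement is available to explain this sameness. Going by these compounds, whether an amine or a carboxylic acid at this place would give a different number stays open, as does the effect of any change on the shared core.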